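Swapping the Phenyl Group on a Sulfonyl Sulfur

This account rests on a few compounds, and the source may have more. Where it says the series, first, only, none or still open, it means among the compounds named here.

In a functional assay on CWR22R cells (Homo sapiens) for antiproliferative activity, read by fluorescence and propidium iodide staining, with a stated time of 96 h (on this read-out lower numbers stand for stronger inhibition and higher numbers for weaker inhibition), compound 1 (`CC(O)(CSc1cc(C(F)(F)F)cc(C(F)(F)F)c1)C(=O)Nc1ccc([N+](=O)[O-])cc1C(F)(F)F`) gives 2290 nM. For compound 2 (`CC(O)(CS(=O)(=O)c1cc(C(F)(F)F)cc(C(F)(F)F)c1)C(=O)Nc1ccc(C#N)cc1C(F)(F)F`) the entry reads "nd(insoluble)" (no result reported). Compound 3 (`CC(O)(CS(=O)(=O)c1cccc(C(F)(F)F)c1)C(=O)Nc1cc(C(F)(F)F)cc(C(F)(F)F)c1`) gives 10300 nM, the higher of the two numbers and so the weaker inhibition, and its gap to compound 1 lies beyond the usual scatter. Compound 4 (`CC(O)(CS(=O)(=O)c1ccccc1OC(F)(F)F)C(=O)Nc1cc(C(F)(F)F)cc(C(F)(F)F)c1`) differs from compound 3 in one place, on a sulfonyl sulfur: 2-(trifluoromethoxy)phenyl in place of 3-(trifluoromethyl)phenyl on a sulfonyl sulfur. Among the measured compounds shown here, no measured pair differs in one place only, so nothing here shows directly what such a swap does. The expected size of the change is a 1.1-fold lower number from compound 3 to compound 4 (0.06 log units; within the scatter), which is none beyond the scatter. For compound 4 the estimated value is 9000 nM, with an expected range of 3500 nM to 23000 nM.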

Compound 4, half-maximal inhibitory concentration: 8990 nM
Estimate against measurement, compound 4: 1.0-fold (0.00 log units) above; measured number inside the range.
By their numbers in this assay, from the lowest: compound 1; then compounds 4 and 3 (each within the scatter of the next).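

Among the compounds shown here, this is the first direct comparison at the sulfonyl sulfur: in this assay, 2-(trifluoromethoxy)phenyl in place of 3-(trifluoromethyl)phenyl gives a 1.1-fold lower number from compound 3 to compound 4 (0.06 log units; within the scatter), so the two groups cannot be told apart here. The entering group brings one more heavy atom and a hydrogen-bond acceptor, yet the number stays within the scatter. Nothing measured here gives a reason for this result. Still open, going by these compounds, is whether an amine or a carboxylic acid on this phenyl ring would shift the number. A plain unsubstituted phenyl on the sulfur is equally untested among the compounds shown.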